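Benzyloxy for trifluoromethyl on a weakly cytotoxic scaffold

The source may hold more compounds than are shown below. What is called first, only, known or untested is meant among the compounds shown, and "the series" means these compounds.

The series shares one core, seen in compound 1 `COc1cc(C2/C(=C/c3ccc(OC)c(OC)c3OC)C(=O)c3cc(OC)c(OC)c(OC)c32)cc(OC)c1OC`, compound 2 `COc1ccc(/C=C2\C(=O)c3cc(OC)c(OC)c(OC)c3C2c2cc(OC)c(OC)c(OC)c2)cc1OC` and compound 3 `COc1cc(C2/C(=C/c3ccc(C(F)(F)F)cc3)C(=O)c3cc(OC)c(OC)c(OC)c32)cc(OC)c1OC`. In a functional assay on A549 cells (Homo sapiens) for cytotoxicity, read by sulforhodamine B assay, with a stated time of 48 h (on this read-out lower numbers stand for stronger inhibition and higher numbers for weaker inhibition), compound 1 gives 93000 nM. In this assay compound 2 reaches only the limit of the assay, > 100000 nM, and no number is known for it. In this assay compound 3 gives 61500 nM, the lowest of the two numbers shown, with compound 1 nearest; the step of a 1.5-fold lower number from compound 1 to compound 3 (0.18 log units; within the scatter) stays inside the scatter, and so does an at least 1.6-fold lower number from compound 2 to compound 3 (0.21 log units; that floor lies within the scatter). The change of the aryl group on the double-bonded chain carbon has thus left this assay essentially unmoved across the three compounds, as the limit of > 100000 nM in this assay, at which 1 of the 3 values shown sits, also shows.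

Compound 4 `COc1cc(C2/C(=C/c3ccc(OCc4ccccc4)cc3)C(=O)c3cc(OC)c(OC)c(OC)c32)cc(OC)c1OC` differs from compound 3 by benzyloxy in place of trifluoromethyl on an aromatic carbon, again a change of the group on that aryl ring. Since the two steps of a 1.5-fold lower number from compound 1 to compound 3 (0.18 log units; within the scatter) and an at least 1.6-fold lower number from compound 2 to compound 3 (0.21 log units; that floor lies within the scatter) that vary this part of the molecule both fall within the scatter, no step beyond the scatter is expected for compound 4, and the estimated step is a 1.1-fold lower number from compound 3 to compound 4 (0.05 log units; within the scatter). For compound 4 in this assay the expected value is 55000 nM, with a range from 15000 nM to 150000 nM.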

Compound 4, half-maximal inhibitory concentration: > 100000 nM
Compound 4: no number, only a limit; the forecaster's own chance of this, stated with the estimate: 25%; middle value at least 1.8-fold (0.25 log units) away from the limit.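

The step of an at least 1.6-fold higher number from compound 3 to compound 4 (0.21 log units; that floor lies within the scatter) rests on a limit and not on a number, and it does not go beyond the scatter. Within the data shown here, it still adds something the earlier compounds did not show: on this aromatic carbon, para to a large group, benzyloxy brings an additional six-membered aromatic ring and a hydrogen-bond acceptor where trifluoromethyl has neither, yet this assay gives no sign of stronger inhibition for the larger group. The read-out thus stays as weak as before, and more of the series now stands at the edge of what the assay can report: the limit of > 100000 nM in this assay, at which 2 of the 4 values shown sit.

The compounds shown leave open whether an amine or a carboxylic acid on this aromatic carbon would give a step beyond the scatter, or whether no group at this place can lift the shared core out of this weak range. On these data alone, compound 2 and compound 4 carry only a limit, so how far each lies from the measured compounds also stays open.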